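Inverting one stereocentre: what compound 4 may show

The compounds below may be only part of what the source reports. "The series", "measured", "known", "first", "only" and "open" are said of these compounds alone.

compound 1 (`CN(CC(=O)N(Cc1ccc(C2CCCCC2)cc1)c1ccc(B(O)O)cc1)S(=O)(=O)c1c(F)c(F)c(F)c(F)c1F`): 1540 nM
compound 2 (`C[C@@H](C(=O)N(Cc1ccc(C2CCCCC2)cc1)c1ccc(B(O)O)cc1)N(C)S(=O)(=O)c1c(F)c(F)c(F)c(F)c1F`): 2570 nM
compound 3 (`O=C([C@H]1CCCN1S(=O)(=O)c1c(F)c(F)c(F)c(F)c1F)N(Cc1ccc(C2CCCCC2)cc1)c1ccc(B(O)O)cc1`): 2780 nM

All three values come from a functional assay on AGS cells (Homo sapiens) for antiproliferative activity, read by CCK-8 assay, with a stated time of 72 h (a higher number here means a weaker inhibitor, a lower number a stronger inhibitor), and they sit close together. In this measure compound 2 gives 2570 nM and lies within the usual scatter of compound 3 at 2780 nM as well as of compound 1 at 1540 nM, so it stands in a tight group with no clear order.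

The next compound is compound 4 (`C[C@H](C(=O)N(Cc1ccc(C2CCCCC2)cc1)c1ccc(B(O)O)cc1)N(C)S(=O)(=O)c1c(F)c(F)c(F)c(F)c1F`). Its relation to compound 2 is simple to state: the two compounds have the same atoms and bonds and differ only in configuration as drawn: 1 of 1 stereo elements differ; a stereocentre at a saturated chain carbon is drawn S in compound 2 and R in compound 4. Nothing is added or removed, and only the drawn configuration at that carbon changes.

Among the compounds with values here, one measured step touches this carbon, the methyl in place of hydrogen (a 1.7-fold higher number from compound 1 to compound 2 (0.22 log units; within the scatter)), and it stays within the scatter. Within the data shown here, that step does not test configuration, and no measured pair differs in configuration alone, so the evidence is indirect. No step beyond the scatter is therefore expected in this assay, and no direction can be firmly predicted.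

The expected change is small (a 1.1-fold lower number from compound 2 to compound 4 (0.05 log units; within the scatter)). Compound 4 is estimated at 2300 nM (expected range 1000 nM to 5000 nM).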

Compound 4, half-maximal inhibitory concentration: 1720 nM
Estimate against measurement, compound 4: 1.3-fold (0.13 log units) above, within the range that was stated.
By their numbers in this assay, from the lowest: compounds 1, 4, 2 and 3 (each within the scatter of the next).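

Within the data shown here, this is the first pair that tests configuration alone, and in this assay inverting the saturated chain carbon gives a 1.5-fold lower number from compound 2 to compound 4 (0.17 log units; within the scatter). Any difference between these two compounds can only come from that one centre, because nothing else separates them: the fact that compounds 2 and 4 differ only in the configuration as drawn. Methyl in place of hydrogen on this carbon, now read with the R configuration, gives a 1.1-fold higher number from compound 1 to compound 4 (0.05 log units; within the scatter), so in this assay neither the methyl, in either drawn configuration, nor the inversion itself moves the number beyond the scatter.

On these data alone, compounds 1, 2 and 4 carry only hydrogen or methyl on this carbon, so what a longer chain, an amine or a carboxylic acid there would do remains open. Whether configuration counts for as little at the stereocentre of compound 3, or in any measure other than this assay, also stays unanswered.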